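Tetrabromo benzotriazole alcohols: stereo-defined versus undefined

The source may hold more compounds than are shown below. What is called first, only, known or untested is meant among the compounds shown, and "the series" means these compounds.

Measured so far:
- compound 1, `OC(CCn1nc2c(Br)c(Br)c(Br)c(Br)c2n1)c1ccc(F)cc1`: 0%
- compound 2, `C[C@H](O)CCn1nc2c(Br)c(Br)c(Br)c(Br)c2n1`: 42%

In a functional assay on CCRF-CEM cells (Homo sapiens) for antiproliferative activity, read by MTT assay, with a stated time of 48 h, tested at 50 uM (a lower number here means a stronger effect, a higher number a weaker effect of the compound at the concentration tested), compound 1 gives 0% and compound 2 gives 42%. Compound 2 stands highest of the two numbers, and its gap to compound 1 lies beyond the scatter. Among the measured compounds shown here, no step between the two measured compounds is defined, as they differ in more than one place.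

The next compound, compound 3, `CC(O)CCn1nc2c(Br)c(Br)c(Br)c(Br)c2n1`, is to be measured in this assay. Its relation to compound 2 is the two compounds have the same atoms and bonds; at least one stereo element is drawn with a configuration in one of them and without one in the other: 1 of 1 stereo elements differ; a stereocentre at a saturated chain carbon is drawn S in compound 2 and without a configuration in compound 3. The atoms and bonds are identical; only the drawn configuration at the chain carbon is dropped.

With no change in composition, the expectation is that compound 3 behaves close to compound 2, and the estimated step of a number 4 percentage points lower from compound 2 to compound 3 (within the scatter) is expected to lie within the scatter or at most slightly lower. In this assay compound 3 is estimated at 38%, within the range 22% to 54%.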

Compound 3, a percentage reported as activity, at one concentration (the size of the read-out at that concentration, not a potency): 45%
Compound 3: the middle estimate sits 7 percentage points below what was measured; measured number inside the range.
By their numbers in this assay, from the lowest: compound 1; then compounds 2 and 3 (each within the scatter of the next).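

In this assay, the drawn configuration at the chain carbon makes no readable difference, with a number 3 percentage points higher from compound 2 to compound 3 (within the scatter). The S form and the form without a drawn configuration therefore cannot be told apart here, and this comparison isolates a single difference: the fact that one of compounds 2 and 3 is drawn with a defined configuration and the other without, at the place where they differ. Among the compounds shown here, compound 3 also gives the first single-place comparison at the carbinol substituent, since methyl in place of 4-fluorophenyl gives a number 45 percentage points higher from compound 1 to compound 3 (beyond the scatter), so the 4-fluorophenyl group goes with the much stronger effect at the concentration tested.

Still open, as far as these compounds go, is how a drawn R configuration at this carbon would read, and what share of each configuration compound 3 holds. Also open, from the compounds shown here alone, is whether a substituent of intermediate size such as ethyl or an unsubstituted phenyl, or an amine in place of the hydroxyl, would keep the low number of compound 1.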